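The source may hold more compounds than are shown below. What is called first, only, known or untested is meant among the compounds shown, and "the series" means these compounds.

In a functional assay on A2780 cells (Homo sapiens) for cytotoxicity, read by sulforhodamine B assay, with a stated time of 72 h (a higher number here means a weaker inhibitor, a lower number a stronger inhibitor), compound 1 `O=C(NCc1ccc(S(=O)(=O)N2CCOCC2)cc1)N1Cc2ccncc2C1` gives 68 nM, compound 2 `O=C(NCc1ccc(S(=O)(=O)N2CCC[C@H](O)C2)cc1)N1Cc2ccncc2C1` gives 150 nM and compound 3 `O=C(NCc1ccc(S(=O)(=O)N2CC3(CCOCC3)C2)cc1)N1Cc2ccncc2C1` gives 10 nM, the lowest of the three numbers. Compound 4 `O=C(NCc1ccc(S(=O)(=O)N2CCC(N3CCCC3)CC2)cc1)N1Cc2ccncc2C1` differs from compound 3 by a group of 11 heavy atoms (9 carbon, 2 nitrogen; one five-membered non-aromatic ring with 1 hetero atom, one six-membered non-aromatic ring with 1 hetero atom) in place of a group of 9 heavy atoms (7 carbon, 1 nitrogen, 1 oxygen; one four-membered non-aromatic ring with 1 hetero atom, one six-membered non-aromatic ring with 1 hetero atom), on a sulfonyl sulfur, the entering group being 4-(pyrrolidin-1-yl)piperidin-1-yl. Three measured changes at this same place bear on it: a 6.8-fold lower number from compound 1 to compound 3 (0.83 log units; beyond the scatter), a 15-fold lower number from compound 2 to compound 3 (1.18 log units; beyond the scatter) and a 2.2-fold higher number from compound 1 to compound 2 (0.34 log units; beyond the scatter). They range from modest to large, yet none involves the entering group, so the guidance is loose. As compound 3 already holds the lowest number, a modest rise in this assay is expected, an estimated 3.0-fold higher number from compound 3 to compound 4 (0.48 log units; beyond the scatter). For compound 4 the expected value is 30 nM, with an estimated range of 8 nM to 110 nM.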

Compound 4, half-maximal inhibitory concentration: 5.6 nM
Compound 4: the middle estimate sits 5.4-fold (0.73 log units) above what was measured; the measured number lies below the stated range.
By their numbers in this assay, from the lowest: compounds 4 and 3 (each within the scatter of the next); then compound 1; then compound 2.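

In this assay, 4-(pyrrolidin-1-yl)piperidin-1-yl on the sulfonyl sulfur stands level with the group of compound 3 (a 1.8-fold lower number from compound 3 to compound 4 (0.25 log units; within the scatter)). It also gives clear gains over the single-ring groups (a 12-fold lower number from compound 1 to compound 4 (1.08 log units; beyond the scatter); a 27-fold lower number from compound 2 to compound 4 (1.43 log units; beyond the scatter)). Among these four compounds, both groups with two rings therefore give lower numbers than morpholin-4-yl and 3-hydroxypiperidin-1-yl, with no compound going against this, although the two groups differ in ring sizes and hetero atoms.

The compounds shown leave open whether the second ring or the second nitrogen matters, which a 4-cyclopentylpiperidin-1-yl group would help separate. No evidence is offered that explains these numbers.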